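Cytotoxicity notes on a boron-containing chalcone series

The source may report more compounds than this note shows. Statements on the series, on what has been measured and on what is new or still open speak of the compounds shown alone.

Measured compounds:
- compound 1 `O=C(/C=C/c1ccc2c(c1)B(O)OC2)c1ccco1`: 59000 nM
- compound 2 `O=C(/C=C/c1ccc2c(c1)B(O)OC2)c1ccc(I)cc1`: > 100000 nM
- compound 3 `O=C(/C=C/c1ccc2c(c1)B(O)OC2)c1ccccc1O`: > 100000 nM

In a toxicity assay on WI-38 cells (Homo sapiens) for cytotoxicity, read by MTT assay, with a stated time of 48 h (on this read-out higher numbers stand for weaker inhibition and lower numbers for stronger inhibition), compound 1 gives 59000 nM. For compound 2 the read-out in this assay is a limit of the assay, > 100000 nM, and not a number. For compound 3 likewise only a limit is known in this assay, namely > 100000 nM; it is one of the two values sitting at the limit of > 100000 nM in this assay, at which 2 of the 3 values shown sit. The step of an at least 1.6-fold higher number from compound 1 to compound 3 (0.22 log units; that floor lies within the scatter), and the step that the two limits leave unreadable from compound 2 to compound 3. Compound 3 therefore stands at the weak end of what has been measured, with no number of its own.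

Compound 4 `Nc1cccc(C(=O)/C=C/c2ccc3c(c2)B(O)OC3)c1` differs from compound 3 by 3-aminophenyl in place of 2-hydroxyphenyl on a carbonyl carbon. Within the data shown here, no measured step involves a 3-aminophenyl, so the only guide is that two of three values already sit at the limit and the one numeric value, from compound 1, is itself weak. In this assay compound 4 is expected to read near the limit again, a step of about a number no higher from compound 3 to compound 4 (the limit leaves the size open), with no change beyond the scatter expected. The estimate for compound 4 is 100000 nM, in the range 40000 nM to 300000 nM.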

Compound 4, half-maximal inhibitory concentration: 25300 nM
For compound 4 the middle estimate is 4.0-fold (0.60 log units) above the measured one; the whole stated range lies above it.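

At this position, on a carbonyl carbon, the group attached clearly moves the read-out in this assay, with an at least 3.9-fold lower number from compound 3 to compound 4 (0.59 log units; beyond the scatter) and an at least 3.9-fold lower number from compound 2 to compound 4 (0.59 log units; beyond the scatter). Compound 2 and compound 3 each remain at a limit of the assay and not at a number: the limit of > 100000 nM in this assay, at which 2 of the 4 values shown sit. The only comparison between two numbers shows a 2.3-fold lower number from compound 1 to compound 4 (0.37 log units; beyond the scatter), so among these four compounds alone, 3-aminophenyl gives the strongest inhibition, and cytotoxicity in this series is not confined to the furan-2-yl compound.

It stays open whether the nitrogen of the 3-aminophenyl group matters or whether other substituted phenyl groups would read the same, as no other nitrogen-bearing group appears among the compounds shown. An acetamide or a carboxylic acid in place of the amine would address that question.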